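Benzyl on the ring nitrogen of compound 2

The compounds below may be only part of what the source reports. "The series", "measured", "known", "first", "only" and "open" are said of these compounds alone.

Compound 2 `NC(=O)c1ccc2[nH]c(-c3ccc(OCC4CCCNC4)cc3)nc2c1` has no single number in a physicochemical assay for solubility, with a stated time of 3 days, at pH 7 (on this read-out higher numbers stand for higher solubility and lower numbers for lower solubility), and its entry reads "not determined" (no result reported). Compound 1 `NC(=O)c1ccc2[nH]c(-c3ccc(OCCCN4CCCCC4)cc3)nc2c1` gives > 400000 nM in this assay, which is a limit of the assay and not a number. The structure then changes (benzyl in place of hydrogen on an amine nitrogen in a ring), with benzyl in place of hydrogen on an amine nitrogen in a ring. This gives compound 3 `NC(=O)c1ccc2[nH]c(-c3ccc(OCC4CCCN(Cc5ccccc5)C4)cc3)nc2c1`. Going by the values given here, no measured step bears on this change, but a moderate downward step in this assay, beyond the usual scatter, is expected. For compound 3 the estimated value is 100000 nM, with an expected range from 20000 nM to 400000 nM.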

Compound 3, solubility: 267000 nM
The estimate for compound 3 lay 2.7-fold (0.43 log units) below the measured number; the range from low to high includes it.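

Compound 2 has no number to set against compound 3, so no step can be read between them in this assay. The compounds shown leave open how benzyl in place of hydrogen on an amine nitrogen in a ring shifts this read-out.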